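Fluoro to trifluoromethyl on the benzyl-type series

This account rests on a few compounds, and the source may have more. Where it says the series, first, only, none or still open, it means among the compounds named here.

Measured in a functional assay on MV4-11 cells (Homo sapiens) for antiproliferative activity, read by luminescence and CellTiter-Glo, with a stated time of 72 h; a lower number here means a stronger inhibitor, a higher number a weaker inhibitor:
- compound 1 `Cc1noc(C)c1-c1ccc(-n2ncc3ccc(-c4c(C)noc4C)cc32)c(Cl)c1`: 2800 nM
- compound 2 `COc1ccc(Cn2nc(Nc3ccc(F)cc3)c3ccc(-c4c(C)noc4C)cc32)cc1`: 9100 nM
- compound 3 `CNc1cc(-c2ccc3cnn(Cc4ccc(F)cc4)c3c2)cn(C)c1=O`: 2390 nM

Compound 3 holds the lowest of the three numbers, though it lies within the scatter of compound 1. Compound 2 gives a higher number than compound 3, beyond the scatter. Compound 4 `CNc1cc(-c2ccc3cnn(Cc4ccc(C(F)(F)F)cc4)c3c2)cn(C)c1=O` differs from compound 3 by trifluoromethyl in place of fluoro on an aromatic carbon, para to a large group. Within the data shown here, no measured pair isolates a single change, so the series offers no step to scale from. No step beyond the scatter is expected in this assay, in either direction. The expected change is a 1.0-fold higher number from compound 3 to compound 4 (0.02 log units; within the scatter). This expectation rests only on compound 3 at 2390 nM. Compound 4 is estimated at 2500 nM, with an expected range of 1000 nM to 6500 nM.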

Compound 4, half-maximal inhibitory concentration: 4370 nM
Beside the measured number, compound 4's estimate is 1.7-fold (0.24 log units) below it; the measured number falls inside the stated range.
By their numbers in this assay, from the lowest: compounds 3, 1 and 4 (each within the scatter of the next); then compound 2.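

In this assay, among these compounds, the first single-change pair of the series gives a 1.8-fold higher number from compound 3 to compound 4 (0.26 log units; within the scatter) and so does not separate 4-fluorophenyl from 4-(trifluoromethyl)phenyl. On this core, the aromatic carbon para to a large group accepts trifluoromethyl in place of fluoro without a step beyond the scatter. Nothing measured here offers an explanation for this result.

Open, as far as these compounds go, is whether an amine or a carboxylic acid at this position would leave the number as little changed. Also open, from the compounds shown here alone, is whether the same change behaves alike on the core of compound 1 or compound 2.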